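Plasma Protein Binding Along a Carboxycyclohexyl Series

The source may hold more compounds than are shown below. What is called first, only, known or untested is meant among the compounds shown, and "the series" means these compounds.

Compound 1 `COc1ccc(F)cc1-c1ccnc2[nH]c(C3=CCN([C@H]4CC[C@@H](C(=O)O)CC4)CC3)cc12` — 92.6%
Compound 2 `COc1ccc(F)cc1-c1c(F)cnc2[nH]c(C3=CCN([C@H]4CC[C@H](C(=O)O)CC4)CC3)cc12` — 94.1%
Compound 3 `COc1ccc(F)cc1-c1c(F)cnc2[nH]c(C3=CCN([C@H]4CC[C@@H](C(=O)O)CC4)CC3)cc12` — 93.4%

In an ADME assay on a cell-free system (plasma, Homo sapiens) for protein binding, compound 3 gives 93.4% and stands second highest of the three values of the unbound fraction; all three compounds sit within the scatter of one another. Two measured steps lead to compound 3. The first, a 1.1-fold lower unbound fraction from compound 1 to compound 3 (0.05 log units; within the scatter), introduces fluoro in place of hydrogen on an aromatic carbon. The second, a 1.1-fold higher unbound fraction from compound 2 to compound 3 (0.05 log units; within the scatter), rests on the fact that compounds 2 and 3 differ only in the configuration as drawn and leaves the number essentially unchanged.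

Compound 4 `COc1ccc(F)cc1-c1c(F)cnc2[nH]c(C3=CCN([C@H]4CC[C@H](CC(=O)O)CC4)CC3)cc12` has not yet been measured. It differs from compound 3 as follows: 4-(carboxymethyl)cyclohexyl in place of 4-carboxycyclohexyl on an amine nitrogen in a ring. Among the compounds with values here, neither measured step touches the group on the ring amine nitrogen, so no direct precedent exists for this change. Within the data shown here, both known steps were within the scatter, and the whole series so far spans a narrow band of high binding. The step a 1.1-fold lower unbound fraction from compound 3 to compound 4 (0.04 log units; within the scatter) is therefore expected to be small, with no clear direction beyond the scatter. For compound 4 a value of 94% is estimated, with a likely range from 90% to 97%.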

Compound 4, plasma protein binding: 95.9%
Compound 4: the middle estimate sits 1.5-fold (0.17 log units) (unbound fraction) above what was measured; the measured number falls inside the stated range.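

This is the first change shown at the group on the ring amine nitrogen, and in this assay the move to 4-(carboxymethyl)cyclohexyl gives a 1.6-fold lower unbound fraction from compound 3 to compound 4 (0.21 log units; within the scatter). Carboxymethyl in place of carboxy on a saturated ring carbon gives a 1.4-fold lower unbound fraction from compound 2 to compound 4 (0.16 log units; within the scatter), so neither route to compound 4 leaves the scatter, and the longer group on the amine nitrogen keeps this series in the same narrow band of high binding that the earlier compounds occupied. The two routes start from compounds that are otherwise closely related, so the change has been read from two configurations of the 4-carboxycyclohexyl group, and their relationship is simple: the fact that compounds 2 and 3 differ only in the configuration as drawn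

The compounds shown leave open whether a longer chain ending in a carboxylic acid, or an amide or a primary amine in place of the acid on the cyclohexyl ring, would produce a step beyond the scatter. They also leave open how the other configuration of the 4-(carboxymethyl)cyclohexyl group would read in this assay, and whether the aromatic fluoro group matters once carboxymethyl is present.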